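Benzyl ether variation in the compound 3 series

The source may report more compounds than this note shows. Statements on the series, on what has been measured and on what is new or still open speak of the compounds shown alone.

Compound 3 `Cc1ccccc1COc1ccccc1C(=O)Nc1cccnc1` gives the lowest number among the three measured compounds in an assay on lysate for inhibition of phosphatidylcholine:ceramide cholinephosphotransferase 2 (Homo sapiens), read by HPLC, with stated times of 30 min and 2 h (a lower number here means a stronger inhibitor, a higher number a weaker inhibitor), at 1500 nM. Among the measured compounds shown here, compound 1 `O=C(NCc1ccccc1)c1ccccc1OCc1ccccc1` gives 34200 nM and compound 2 `O=C(Nc1ccccn1)c1ccccc1OCc1ccccc1` gives 11700 nM; the only single-point step, a 2.9-fold lower number from compound 1 to compound 2 (0.47 log units; beyond the scatter), sits on the amide nitrogen and leaves the benzyl ether untouched. Compound 4 `O=C(Nc1cccnc1)c1ccccc1OCc1cc(Cl)ccc1Cl` differs from compound 3 by 2,5-dichlorophenyl in place of 2-methylphenyl on a saturated chain carbon bound to an oxygen on an aromatic ring. For the measured compounds named here, no measured step alters this ring, so neither direction nor size is anchored by the data; the gap between compound 2 and compound 3 spans two changes at once and cannot be separated. A step of moderate size is expected, stated as a 1.7-fold lower number from compound 3 to compound 4 (0.22 log units; within the scatter). Compound 4 is therefore expected to give 900 nM, with a range from 250 nM to 3500 nM.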

Compound 4, half-maximal inhibitory concentration: 990 nM
Estimate against measurement, compound 4: 1.1-fold (0.04 log units) below; the measured number falls inside the stated range.
By their numbers in this assay, from the lowest: compounds 4 and 3 (each within the scatter of the next); then compound 2; then compound 1.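

In this assay the position on a saturated chain carbon bound to an oxygen on an aromatic ring now has its first measured step (a 1.5-fold lower number from compound 3 to compound 4 (0.18 log units; within the scatter)). Within the scatter, 2,5-dichlorophenyl and 2-methylphenyl cannot be told apart here, so this position holds the two chlorine-bearing ring without a measurable loss. No measurement available here bears on this result.

Open, going by these compounds, is what an amine or a carboxylic acid on this ring would give, and what each chlorine contributes alone. The gap from compound 2 to compound 3 also remains unsplit between its two changes.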